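From chloro to cyano: compound 1 and compound 4

The source may hold more compounds than are shown below. What is called first, only, known or untested is meant among the compounds shown, and "the series" means these compounds.

In an ADME assay on microsomes from liver (Mus musculus) for metabolic stability, read by LC-MS, using NADPH, with a stated time of 10 min, tested at 0.5 uM (on this read-out higher numbers stand for a more stable compound and lower numbers for a less stable compound), compound 1 (`COC(=O)Nc1cc(-c2cnc(OC[C@@](C)(N)CC(C)C)c(Cl)c2)ccn1`) gives 65% and serves as the starting point for this step. Compound 2 (`COC(=O)Nc1cc(-c2ccc(OC[C@@](C)(N)CC(C)C)c(F)c2)ccn1`) at 71% lies within the scatter of compound 1, so the two count as level. Compound 3 (`CC(=O)Nc1cc(-c2ccc(OC[C@@H](N)CC(C)C)c(Cl)c2)ccn1`) at 86% stands higher than compound 1 by a gap beyond the scatter.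

The compound still to be measured is compound 4 (`COC(=O)Nc1cc(-c2cnc(OC[C@@](C)(N)CC(C)C)c(C#N)c2)ccn1`). Its difference from compound 1 is as follows: cyano in place of chloro on an aromatic carbon (cyano in place of chloro on an aromatic carbon, ortho to a (2-amino-2,4-dimethylpentyl)oxy group).

For the measured compounds named here, no two measured compounds differ in one place, so the data give no direct size for this swap. The expectation therefore starts from compound 1 at 65% and takes the width of its range from the spread in the series, whose far end is compound 3 at 86%. The expected change is a number 5 percentage points higher from compound 1 to compound 4 (within the scatter) in this assay and amounts to a slight upward move that stays within the scatter. Compound 4 is estimated at 70% with an expected range from 52% to 86% as the working figure.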

Compound 4, percent of the compound remaining: 86%
For compound 4 the middle estimate is 16 percentage points below the measured one, and the stated range covers the measured number.
By their numbers in this assay, from the lowest: compounds 1 and 2 (each within the scatter of the next); then compounds 3 and 4 (each within the scatter of the next).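

In this assay, the one-place swap of chloro for cyano on this aromatic carbon gives a number 21 percentage points higher from compound 1 to compound 4 (beyond the scatter), the first direct size for any single change in the series. It shows that this position, ortho to a (2-amino-2,4-dimethylpentyl)oxy group and two atoms from the ring nitrogen, is not a silent one: exchanging a single chlorine atom for a cyano group, with its triple bond and one hydrogen-bond acceptor, moves the read-out beyond the scatter while the rest of compound 1 stays unchanged. Nothing at hand bears on why the step arises, so it stands as an observed size for this one pair only.

Going by these compounds, whether the step is specific to cyano remains open, since a single pair cannot tell how a methyl, methoxy or trifluoromethyl group on the same carbon would compare with chloro and cyano. For the compounds shown here, it is also open whether the same swap gives a step of similar size on the other cores, such as the one without the ring nitrogen or the one carrying the acetamide, as no pair here tests either.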